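The source may hold more compounds than are shown below. What is called first, only, known or untested is meant among the compounds shown, and "the series" means these compounds.

Compound 1 `CCCCn1ccnc1-c1cc(OC)c(OC)c(OC)c1`: > 100000 nM
Compound 2 `COc1cc(OC)cc(-n2ccnc2-c2cc(OC)c(OC)c(OC)c2)c1`: > 100000 nM

Both numbers come from a functional assay on T47D cells (Homo sapiens) for antiproliferative activity, read by MTT assay, with a stated time of 72 h; a lower number here means a stronger inhibitor, a higher number a weaker inhibitor. For compound 1 the entry > 100000 nM is not a measurement but a limit of the assay. For compound 2 the entry > 100000 nM is a limit as well. For the measured compounds named here, compound 1 therefore stands at the edge of what this assay can see, as the limit of > 100000 nM in this assay, at which 2 of the 2 values shown sit, sums up: every value known so far sits at that limit, and nothing separates the two compounds.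

Compound 3 `COc1ccc(-n2ccnc2-c2cc(OC)c(OC)c(OC)c2)cc1` has not yet been measured. Its change from compound 1 is 4-methoxyphenyl in place of butyl on an aromatic nitrogen. Going by the values given here, no measured pair differs in one place, so no step size can be read off the data. Compound 2 also carries an aromatic ring on the aromatic nitrogen of the five-membered ring and sits at the limit > 100000 nM. The step of a number no higher from compound 1 to compound 3 (the limit leaves the size open) is therefore expected to be none beyond the scatter. Compound 3 is expected to give about 100000 nM, with a likely range from 30000 nM to 300000 nM, and most probably only a limit will be reported again.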

Compound 3, half-maximal inhibitory concentration: 1400 nM
Compound 3: middle estimate off by 71-fold (1.85 log units), on the high side, and the stated range ends above it.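

Putting 4-methoxyphenyl in place of butyl on the aromatic nitrogen gives an at least 71-fold lower number from compound 1 to compound 3 (1.85 log units; beyond the scatter) in this assay, so the group on this nitrogen can shift the result well beyond the scatter. An aromatic ring there does not guarantee activity, however: compound 2 also carries one, and its entry of > 100000 nM is a limit of the assay. Compound 3 is the only compound here with a real number rather than a limit, which gives later changes a value they can be compared against, something the other entries cannot offer: the limit of > 100000 nM in this assay, at which 2 of the 3 values shown sit.

The compounds shown cannot separate what the aromatic ring contributes from what the methoxy group on it contributes, and they cannot tell how much the placement of that methoxy group matters. A plain phenyl, a 4-chlorophenyl or a benzyl group on the same nitrogen, each compared directly with compound 3, would begin to pull these contributions apart.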